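The source may report more compounds than this note shows. Statements on the series, on what has been measured and on what is new or still open speak of the compounds shown alone.

In a functional assay on MCF7 cells (Homo sapiens) for cytotoxicity, read by MTT assay, with a stated time of 6 days (a lower number here means that less compound is needed, a higher number that more compound is needed for the effect), compound 1 `COC(=O)c1c(-c2ccc(OC)cc2)oc2ccccc2c1=O` gives > 25 ug/mL as a limit. Compound 2 `COC(=O)c1c(-c2ccc(Br)cc2)oc2ccccc2c1=O` gives > 25 ug/mL as a limit too. Compound 3 `COC(=O)c1c(-c2ccc(OCc3ccccc3)cc2)oc2ccccc2c1=O` gives > 25 ug/mL as a limit as well, so no number places it. The whole series rests on the limit of > 25 ug/mL in this assay, at which 3 of the 3 values shown sit, and on no measured number.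

Compound 4 `COC(=O)c1c(-c2ccc(O)cc2)oc2ccccc2c1=O` follows from compound 3 by hydrogen in place of benzyl on an oxygen on an aromatic ring in one change: hydrogen in place of benzyl on an oxygen on an aromatic ring, or benzyloxy to hydroxy. Among the compounds with values here, three measured steps touch this same substituent: a step that the two limits leave unreadable from compound 1 to compound 3 and a step that the two limits leave unreadable from compound 2 to compound 3 and also a step that the two limits leave unreadable from compound 1 to compound 2 in the series. None of them offers a size to carry forward. No step beyond the scatter is therefore expected in this assay and no direction is favoured. The expected change is a step that the limit leaves unreadable from compound 3 to compound 4 on that reading. Compound 4 is estimated at 30 ug/mL with an expected range of 10 ug/mL to 60 ug/mL and may well return only a limit.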

Compound 4, concentration for half-maximal effect: > 25 ug/mL
Compound 4: no number, only a limit (the forecaster's own chance of this, stated with the estimate: 70%); the middle value does not contradict the limit.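

In this assay compound 4 gives > 25 ug/mL, which is a limit. Within the data shown here, no step among compound 1, compound 2, compound 3 and compound 4 can therefore be read. The compounds shown leave open whether any of these substituents on the shared core changes the read-out, as the series still holds no measured number: the limit of > 25 ug/mL in this assay, at which 4 of the 4 values shown sit.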